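Aryl Ketones in Place of Cyclopropyl on a Shared Core

This account rests on a few compounds, and the source may have more. Where it says the series, first, only, none or still open, it means among the compounds named here.

Compound 1 `COc1cc(-c2nnc3n2NC(c2ccco2)C(C(=O)C2CC2)S3)cc(OC)c1OC` carries a cyclopropyl ketone on its core. In a functional assay on PC-3 cells (Homo sapiens) for cytotoxicity, read by MTT assay, with a stated time of 48 h (a lower number here means a stronger inhibitor, a higher number a weaker inhibitor), compound 1 gives 95200 nM. Two neighbours differ from it only at the carbonyl carbon. Compound 2 `COc1cc(-c2nnc3n2NC(c2ccco2)C(C(=O)c2ccccc2F)S3)cc(OC)c1OC` bears a 2-fluorophenyl there, and in this assay compound 2 returns only a limit, > 100000 nM. That exchange reads an at least 1.0-fold higher number from compound 1 to compound 2 (0.02 log units; that floor lies within the scatter). Compound 3 `COc1cc(-c2nnc3n2NC(c2ccco2)C(C(=O)c2ccc(C(F)(F)F)cc2)S3)cc(OC)c1OC` bears a 4-(trifluoromethyl)phenyl, and in this assay compound 3 gives 77500 nM, a step of a 1.2-fold lower number from compound 1 to compound 3 (0.09 log units; within the scatter). Among the numbers themselves compound 1 sits highest of the two, with compound 3 nearest at a step within the scatter, while the third value is a limit (the limit of > 100000 nM in this assay, at which 1 of the 3 values shown sits).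

Compound 4 `COc1cccc(C(=O)C2Sc3nnc(-c4cc(OC)c(OC)c(OC)c4)n3NC2c2ccco2)c1` continues the same exchange: 3-methoxyphenyl in place of cyclopropyl on a carbonyl carbon. Both earlier replacements of cyclopropyl by an aryl ring on the carbonyl carbon left the read-out within the scatter, and the 3-methoxyphenyl is expected to do the same, so the step from compound 1 is estimated as a 1.1-fold lower number from compound 1 to compound 4 (0.02 log units; within the scatter). For compound 4 in this assay a value of 90000 nM is expected, with a range from 45000 nM to 180000 nM.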

Compound 4, half-maximal inhibitory concentration: 84600 nM
Compound 4: middle estimate off by 1.1-fold (0.03 log units), on the high side; measured number inside the range.
By their numbers in this assay, from the lowest: compounds 3, 4 and 1 (each within the scatter of the next). At a limit, above all of these: compound 2.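

With compound 4, the exchange on the carbonyl carbon now covers a ring with an oxygen-bearing substituent, and in this assay the step still reads a 1.1-fold lower number from compound 1 to compound 4 (0.05 log units; within the scatter), while the comparison with the other aryl ketone that has a number reads a 1.1-fold higher number from compound 3 to compound 4 (0.04 log units; within the scatter). The 3-methoxyphenyl brings 8 heavy atoms and a hydrogen-bond acceptor in place of the 3 heavy atoms of cyclopropyl, and neither of these steps leaves the scatter, so among compounds 1, 3 and 4 the read-out does not separate a cyclopropyl from either substituted phenyl. The third comparison reads an at least 1.1-fold lower number from compound 2 to compound 4 (0.07 log units; that floor lies within the scatter), and it gives only a floor, as compound 2 has a limit and not a number: the limit of > 100000 nM in this assay, at which 1 of the 4 values shown sits.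

The compounds shown leave open whether any group on this carbonyl carbon can move the read-out beyond the scatter. From the compounds shown here alone, whether a phenyl ring bearing an amine or a carboxylic acid, or a longer alkyl chain in place of cyclopropyl, would do so remains unknown.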